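The source may report more compounds than this note shows. Statements on the series, on what has been measured and on what is new or still open speak of the compounds shown alone.

Working notes on the series in a toxicity assay on HepG2 2.2.15 cells (Homo sapiens) for cytotoxicity, read by CellTiter-Glo; on this read-out lower numbers stand for higher toxicity in this test and higher numbers for lower toxicity in this test. Compound 1 `N#CC1CC(=O)N(c2cnn3c2CN(C(=O)Nc2cc(F)c(F)c(F)c2)C(C2CC2)C3)C1` reads > 200000 nM, which is a limit of the assay and not a number. Compound 2 `O=C1CC(C(F)(F)F)CN1c1cnn2c1CN(C(=O)Nc1cc(F)c(F)c(F)c1)C(C1CC1)C2` gives 115000 nM and compound 3 `O=C1CC(c2cnco2)CN1c1cnn2c1CN(C(=O)Nc1cc(F)c(F)c(F)c1)C(C1CC1)C2` gives 139000 nM, so these two stand level within the scatter.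

The next change, to compound 4 `O=C(Nc1cc(F)c(F)c(F)c1)N1Cc2c(-c3ccc(F)cc3)cnn2CC1C1CC1`, is 4-fluorophenyl in place of 4-(1,3-oxazol-5-yl)-2-oxopyrrolidin-1-yl on an aromatic carbon.

The measured steps bear on this only indirectly. They are an at least 1.7-fold lower number from compound 1 to compound 2 (0.24 log units; that floor lies within the scatter), an at least 1.4-fold lower number from compound 1 to compound 3 (0.15 log units; that floor lies within the scatter) and a 1.2-fold higher number from compound 2 to compound 3 (0.08 log units; within the scatter). Each swaps only a group on a saturated ring carbon, and none removes the whole group that leaves here. Among the measured compounds shown here, with no measured step of this kind, the expectation rests on the size of the structural change and stays loose. A moderate move towards a lower number is expected, and the expected step is a 2.3-fold lower number from compound 3 to compound 4 (0.36 log units; beyond the scatter). Compound 4 is estimated at 60000 nM, with an expected range of 15000 nM to 200000 nM.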

Compound 4, half-maximal cytotoxic concentration: 38500 nM
Estimate against measurement, compound 4: 1.6-fold (0.19 log units) above, and the stated range covers the measured number.
By their numbers in this assay, from the lowest: compound 4; then compounds 2 and 3 (each within the scatter of the next). At a limit, above all of these: compound 1.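

At this aromatic carbon, replacing the whole substituent moves the number in this assay beyond the scatter, which the swaps on a saturated ring carbon did not show: 4-fluorophenyl in place of 4-(1,3-oxazol-5-yl)-2-oxopyrrolidin-1-yl gives a 3.6-fold lower number from compound 3 to compound 4 (0.56 log units; beyond the scatter), and in place of 2-oxo-4-(trifluoromethyl)pyrrolidin-1-yl it gives a 3.0-fold lower number from compound 2 to compound 4 (0.48 log units; beyond the scatter). In place of 4-cyano-2-oxopyrrolidin-1-yl the same change gives an at least 5.1-fold lower number from compound 1 to compound 4 (0.71 log units; beyond the scatter), so all three steps point towards higher toxicity in this test. Compound 1 stands at a limit, so its step is a floor only: the limit of > 200000 nM in this assay, at which 1 of the 4 values shown sits.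

The compounds shown do not separate the loss of the oxopyrrolidinyl ring from the arrival of the 4-fluorophenyl, or the fluorine from the phenyl ring. On these data alone, how a plain phenyl or an amine at this aromatic carbon would read remains open.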